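Fluorine on the Benzyl Group After a Core Swap

The source may hold more compounds than are shown below. What is called first, only, known or untested is meant among the compounds shown, and "the series" means these compounds.

Measured compounds in an assay on HEK293 cells for inhibition of Ataxin-2 (Mus musculus), read by fluorescence and Amplex Red; on this read-out higher numbers stand for weaker inhibition and lower numbers for stronger inhibition:
compound 1 `CC1(C)OB(c2ccc(COc3ccc(CNC(=O)[C@@H]4CCC(=O)N4Cc4ccccc4)cc3)cc2)OC1(C)C` gives 50 nM;
compound 2 `CC1(C)OB(c2ccc(COc3ccc(CNC(=O)[C@@H]4CCC(=O)N4Cc4ccc(F)cc4)cc3)cc2)OC1(C)C` gives 120 nM;
compound 3 `O=C(NCc1ccc(OCc2ccc(-c3nn[nH]n3)cc2)cc1)[C@@H]1CCC(=O)N1Cc1ccccc1` sits at a limit of this assay, > 5000 nM, which is not a number.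

Compound 1 and compound 2 share a core and differ only by fluoro in place of hydrogen on an aromatic carbon. That change gave a 2.4-fold higher number from compound 1 to compound 2 (0.38 log units; beyond the scatter). Compound 3 differs from compound 1 in its core by a group of 5 heavy atoms (1 carbon, 4 nitrogen; one five-membered aromatic ring with 4 hetero atoms) in place of a group of 9 heavy atoms (6 carbon, 1 boron, 2 oxygen; one five-membered non-aromatic ring with 3 hetero atoms), on an aromatic carbon, and the result was an at least 100-fold higher number from compound 1 to compound 3 (2.00 log units; beyond the scatter); compound 3 reaches (the limit of > 5000 nM in this assay, at which 1 of the 3 values shown sits), so only a limit is known for it.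

Compound 4 `O=C(NCc1ccc(OCc2ccc(-c3nn[nH]n3)cc2)cc1)[C@@H]1CCC(=O)N1Cc1ccc(F)cc1` has not been measured. It stands to compound 3 as compound 2 stands to compound 1: the difference is fluoro in place of hydrogen on an aromatic carbon, and the place is the same in both pairs, so it is the same change made on a different core.

In this assay the same change on the earlier core gave a modest weakening in compound 2; on the core of compound 3, which already sits at a limit, compound 4 is expected to show a step that the limit leaves unreadable from compound 3 to compound 4, resting on the step from compound 1 to compound 2. Compound 4 is therefore estimated at 12000 nM, most likely reported again only as a limit, with a range from 5000 nM to 40000 nM.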

Compound 4, half-maximal inhibitory concentration: > 5000 nM
Compound 4 gave a limit, no number; the forecaster's own chance of this, stated with the estimate: 90%; the middle value lies beyond the limit too.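

In this assay compound 4 gives > 5000 nM, a limit and not a number, and compound 3 sits at a limit too, so the step between them cannot be read, and the modest weakening seen with fluoro on the earlier core is neither confirmed nor ruled out on this one. What can be read is the exchange of the boron-containing group for the five-membered aromatic ring with 4 hetero atoms, which gave an at least 41-fold higher number from compound 2 to compound 4 (1.61 log units; beyond the scatter) among the 4-fluorobenzyl compounds and so lost much strength on both the benzyl and the 4-fluorobenzyl side: the same change on two cores in this assay, an at least 100-fold higher number (2.00 log units; beyond the scatter) from compound 1 to compound 3 and an at least 41-fold higher number (1.61 log units; beyond the scatter) from compound 2 to compound 4; the limit leaves it open whether they differ. Any effect of fluoro on this core stays hidden, and the compounds at the limit are a large part of this small set: the limit of > 5000 nM in this assay, at which 2 of the 4 values shown sit.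

The compounds shown leave open whether a carboxylic acid or an amine in place of the boron-containing group would give a number rather than a limit, so that the fluoro change could be read on a second core. They also leave open how chloro or methyl in place of the fluoro would behave on the benzyl group.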